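The source may hold more compounds than are shown below. What is called first, only, known or untested is meant among the compounds shown, and "the series" means these compounds.

Compound 1, `COc1cc2ncnc(Nc3ccc(Cl)cc3)c2cc1OCCCCC(=O)Nc1ccc(S(N)(=O)=O)cc1`, gives > 40000 nM in a functional assay on A549 cells (Homo sapiens) for antiproliferative activity, read by MTT assay, with a stated time of 72 h; on this read-out higher numbers stand for weaker inhibition and lower numbers for stronger inhibition.
Compound 2, `COc1cc2ncnc(Nc3ccc(F)c(Br)c3)c2cc1OCCCCC(=O)Nc1ccc(S(N)(=O)=O)cc1`, gives 16000 nM.
Compound 3, `COc1cc2ncnc(Nc3ccc(OC(F)(F)F)cc3)c2cc1OCCCCC(=O)Nc1ccc(S(N)(=O)=O)cc1`, gives > 40000 nM.

Compound 1 stands only at a limit: its value in this assay is a limit of the assay and not a number, and two of the three values shown sit at that same limit (the limit of > 40000 nM in this assay, at which 2 of the 3 values shown sit). Compound 4, `COc1cc2ncnc(Nc3cccc(C)c3)c2cc1OCCCCC(=O)Nc1ccc(S(N)(=O)=O)cc1`, differs from compound 1 in one place: 3-methylphenyl in place of 4-chlorophenyl on a nitrogen on an aromatic ring. Two measured steps exchange the aryl group on the same nitrogen and therefore bear on this change. The step of an at least 2.5-fold lower number from compound 1 to compound 2 (0.39 log units; beyond the scatter) shows that such an exchange can bring the number down from the limit to a readable value. The step of an at least 2.5-fold higher number from compound 2 to compound 3 (0.39 log units; beyond the scatter) shows a return to the limit. The step that the two limits leave unreadable from compound 1 to compound 3 runs between two limits and cannot be read. None of these steps involves a methyl group, so they do not fix the size of the step to compound 4. With two of the three values shown at the limit, compound 4 is expected to remain near that limit, with an estimated step of a number no higher from compound 1 to compound 4 (the limit leaves the size open). The estimate for compound 4 in this assay is 40000 nM, with an expected range from 12000 nM to 120000 nM.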

Compound 4, half-maximal inhibitory concentration: 16000 nM
Estimate against measurement, compound 4: 2.5-fold (0.40 log units) above; the measured number falls inside the stated range.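

In this assay, placing 3-methylphenyl on this nitrogen gives an at least 2.5-fold lower number from compound 1 to compound 4 (0.39 log units; beyond the scatter), and the same group gives an at least 2.5-fold lower number from compound 3 to compound 4 (0.39 log units; beyond the scatter), so a readable value here does not require the bromine and fluorine of compound 2. The comparison with that compound shows no change at the digits printed from compound 2 to compound 4 (within the scatter), and among the compounds shown, the 3-methylphenyl of compound 4 and the 3-bromo-4-fluorophenyl of compound 2 give readable values, with no compound going against this. Compound 1, with 4-chlorophenyl, and compound 3, with 4-(trifluoromethoxy)phenyl, both stay at a limit of the assay, which is not a number: the limit of > 40000 nM in this assay, at which 2 of the 4 values shown sit.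

The compounds shown leave open whether 3-chlorophenyl or unsubstituted phenyl on this nitrogen would give a readable value, and therefore whether the readable values follow the place of the substituent or the substituent itself. They also leave open how the values would respond to a longer chain in the linker or to a carboxylic acid in place of the sulfonamide, since all four compounds share those parts.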